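The compounds below may be only part of what the source reports. "The series", "measured", "known", "first", "only" and "open" are said of these compounds alone.

In a functional assay on A549 cells (Homo sapiens) for inhibition, read by MTT assay, with a stated time of 72 h (on this read-out higher numbers stand for weaker inhibition and lower numbers for stronger inhibition), three compounds have been measured:

Compound 1 `O=C(CCC(=O)OCCCCCCSc1ccc([N+](=O)[O-])c2nonc12)Nc1ccccc1F`: 2440 nM
Compound 2 `Cc1ccccc1NC(=O)CCC(=O)OCCCCCCSc1ccc([N+](=O)[O-])c2nonc12`: 4200 nM
Compound 3 `CCN(CC)CCCNC(=O)CCC(=O)OCCCCCCSc1ccc([N+](=O)[O-])c2nonc12`: 2570 nM

Compound 1 gives the smallest of these three numbers, yet the steps of a 1.7-fold higher number from compound 1 to compound 2 (0.24 log units; within the scatter) and a 1.1-fold higher number from compound 1 to compound 3 (0.02 log units; within the scatter) both fall inside the scatter, so no order among the three is established. Compound 4 `O=C(CCC(=O)N1CCCCC1)OCCCCCCSc1ccc([N+](=O)[O-])c2nonc12` differs from compound 1 by piperidin-1-yl in place of (2-fluorophenyl)amino on a carbonyl carbon. Going by the values given here, the step that bears most on this change is the one from compound 1 to compound 3, where an aromatic amide substituent gave way to an aliphatic one with a 1.1-fold higher number from compound 1 to compound 3 (0.02 log units; within the scatter); the step of a 1.6-fold lower number from compound 2 to compound 3 (0.21 log units; within the scatter) points the same way. Compound 4 is therefore expected to show a 1.1-fold higher number from compound 1 to compound 4 (0.03 log units; within the scatter), no step beyond the scatter. Compound 4 is estimated at 2600 nM, within 1200 nM to 5600 nM.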

Compound 4, half-maximal inhibitory concentration: 2510 nM
Beside the measured number, compound 4's estimate is 1.0-fold (0.02 log units) above it; measured number inside the range.
By their numbers in this assay, from the lowest: compounds 1, 4, 3 and 2 (each within the scatter of the next).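

In this assay, piperidin-1-yl on this carbonyl carbon removes the amide hydrogen that compounds 1, 2 and 3 all carry, yet the number stays within the scatter of all three (a 1.0-fold higher number from compound 1 to compound 4 (0.01 log units; within the scatter); a 1.0-fold lower number from compound 3 to compound 4 (0.01 log units; within the scatter); a 1.7-fold lower number from compound 2 to compound 4 (0.22 log units; within the scatter)). Across these four compounds, then, neither that hydrogen nor an aromatic ring in this group separates the numbers. Nothing available explains this result.

Going by these compounds, it remains open whether a carboxylic acid or morpholin-4-yl at this carbonyl carbon would keep the number in this range. On these data alone, it also remains open whether any group here can move it beyond the scatter.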